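Compound 2 loses its pyrimidin-2-yl group

The source may hold more compounds than are shown below. What is called first, only, known or untested is meant among the compounds shown, and "the series" means these compounds.

In a functional assay on OVCAR-3 cells (Homo sapiens) for antiproliferative activity, read by sulforhodamine B assay, with a stated time of 72 h (a higher number here means a weaker inhibitor, a lower number a stronger inhibitor), compound 1 `CCN1C(=O)CS/C1=N/Nc1nncc2ccccc12` gives 55 nM, compound 2 `O=S(=O)(Nc1ncccn1)c1ccc(Nc2nncc3ccccc23)cc1` gives 72 nM and compound 3 `COc1ccc(NC(=S)NNc2nncc3ccccc23)cc1` gives 73 nM. Compound 2 lies within the scatter of both other compounds, so no order can be read among the three.

The next compound to be tested is compound 4 `NS(=O)(=O)c1ccc(Nc2nncc3ccccc23)cc1`. It differs from compound 2 in one place, with hydrogen in place of pyrimidin-2-yl on a sulfonamide nitrogen. For the measured compounds named here, no measured pair shows this change, so its size has no direct precedent. Going by the values given here, the only guide is the narrow spread of the series: the groups on the shared core differ widely, yet compound 1 at 55 nM and compound 3 at 73 nM remain within the scatter of each other. A small change towards weaker inhibition is therefore expected in this assay, with an estimated step of a 1.5-fold higher number from compound 2 to compound 4 (0.18 log units; within the scatter). The estimated value for compound 4 is 110 nM, within an expected range of 40 nM to 300 nM.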

Compound 4, half-maximal inhibitory concentration: 14 nM
For compound 4 the middle estimate is 7.9-fold (0.90 log units) above the measured one; the whole stated range lies above it.
By their numbers in this assay, from the lowest: compound 4; then compounds 1, 2 and 3 (each within the scatter of the next).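

Within this assay, the sulfonamide nitrogen is the first place in the series where a single change can be read, and the step is beyond the scatter: hydrogen in place of pyrimidin-2-yl gives a 5.1-fold lower number from compound 2 to compound 4 (0.71 log units; beyond the scatter). Pyrimidin-2-yl is therefore not required on this nitrogen for activity in this assay, and the unsubstituted sulfonamide is the better of the two forms shown. No measurement at hand accounts for the step.

This one pair cannot separate the loss of the aromatic ring from the presence of the free amino group on the sulfonyl sulfur. Going by these compounds, a methyl or acetyl group on the same nitrogen, or a phenyl ring in place of pyrimidin-2-yl, would bear on that question, and whether the step carries over to other substituents remains open.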